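Prop-1-yn-1-yl to isopropyl on the shared core

A few compounds are considered here, and "the series" means these few. Any claim that something is new, unique, unknown or untested is made for them only; others in the source may bear on it.

- compound 1 (`CC#CCOc1noc2c1CNCC2`) gives 7.6
- compound 2 (`c1ccc(COc2noc3c2CNCC3)cc1`) gives 7.5

Within the data shown here, both values come from a physicochemical assay for acid dissociation, and are the only measurements so far. Compound 1 stands level with compound 2, since the two values lie within the usual scatter of each other.

Compound 3 (`CC(C)COc1noc2c1CNCC2`) has not yet been measured. It departs from compound 1 in one place (isopropyl in place of prop-1-yn-1-yl on a saturated chain carbon bound to an oxygen on an aromatic ring), with isopropyl in place of prop-1-yn-1-yl on a saturated chain carbon bound to an oxygen on an aromatic ring. Among the measured compounds shown here, no measured pair shows this change or any other single change, so the expectation has little support. For the measured compounds named here, the one guide is that compound 1 (7.6) and compound 2 (7.5) do not separate beyond the scatter in this assay. A small rise, not beyond the scatter, is therefore expected. The expected step (a number 0.10 log units higher from compound 1 to compound 3 (within the scatter)) is tentative. For compound 3 the estimated value is 7.7 (expected range 7.4 to 8).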

Compound 3, acid dissociation constant: 7.7
For compound 3 middle estimate and measured number coincide at the digits printed; measured number inside the range.
By their numbers in this assay, from the lowest: compounds 2, 1 and 3 (each within the scatter of the next).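

In this assay, the pair of compound 1 and compound 3 gives the series its first step that differs in one place, and that step reads a number 0.10 log units higher from compound 1 to compound 3 (within the scatter). At this place, on a saturated chain carbon bound to an oxygen on an aromatic ring, isopropyl in place of prop-1-yn-1-yl removes the triple bond while keeping 3 heavy atoms, all carbon, and this exchange does not separate the two compounds beyond the scatter. No measured evidence in the series bears on what lies behind this reading.

Among these compounds, only two groups of 3 carbon have been compared directly at this place, so it stays open whether an amine, a carboxylic acid or a longer chain there would also stay within the scatter of compound 1 in this assay. A single step also cannot show whether the same exchange would read alike on another core, so the result holds for this pair alone and gives no trend for the position.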